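The compounds below may be only part of what the source reports. "The series", "measured", "known", "first", "only" and "open" are said of these compounds alone.

Measured compounds:
compound 1 `Fc1cccc(-c2nc(Nc3ccccc3)c3cc(F)ccc3n2)c1`, 48300 nM
compound 2 `COc1ccc(Nc2nc(-c3cccc(F)c3)nc3ccc(F)cc23)cc1`, 42300 nM
compound 3 `Fc1ccc(Nc2nc(-c3cccc(F)c3)nc3ccc(F)cc23)cc1`, > 50000 nM (a limit)

In a functional assay on HT29-AK cells (Homo sapiens) for cytotoxicity, read by MTT assay, with a stated time of 48 h (on this read-out lower numbers stand for stronger inhibition and higher numbers for weaker inhibition), compound 1 gives 48300 nM and compound 2 gives 42300 nM. For compound 3 this assay reports only a limit, > 50000 nM, which is the limit of > 50000 nM in this assay, at which 1 of the 3 values shown sits. The steps of a 1.1-fold lower number from compound 1 to compound 2 (0.06 log units; within the scatter), an at least 1.0-fold higher number from compound 1 to compound 3 (0.01 log units; that floor lies within the scatter) and an at least 1.1-fold higher number from compound 2 to compound 3 (0.07 log units; that floor lies within the scatter) all lie within the scatter, so methoxy or fluoro on the phenyl attached to the nitrogen has not shifted the number. Compound 4 `Fc1cccc(-c2nc(Nc3ccccc3F)c3cc(F)ccc3n2)c1` differs from compound 3 by 2-fluorophenyl in place of 4-fluorophenyl on a nitrogen on an aromatic ring. Among the compounds with values here, no measured step moves a fluoro about this phenyl, so the flat run of steps above is the only guide. No step beyond the scatter is expected, a number no higher from compound 3 to compound 4 (the limit leaves the size open), and compound 4 is estimated at 50000 nM, range 20000 nM to 150000 nM, most likely again reported only as a limit.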

Compound 4, half-maximal inhibitory concentration: > 50000 nM
Compound 4 ended at the assay's limit; the forecaster's own chance of this, stated with the estimate: 65%; the middle value lies on the limit itself.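

In this assay compound 4, like compound 3, is reported only as a limit, so the 2-fluorophenyl and the 4-fluorophenyl on this nitrogen end at the same place: the limit of > 50000 nM in this assay, at which 2 of the 4 values shown sit. The step between those two cannot be read. The readable steps are an at least 1.1-fold higher number from compound 2 to compound 4 (0.07 log units; that floor lies within the scatter) and an at least 1.0-fold higher number from compound 1 to compound 4 (0.01 log units; that floor lies within the scatter) and both floors lie within the scatter, so no change on this phenyl has yet moved the number.

As far as these compounds go, whether an amine or a carboxylic acid on this phenyl would bring a value clear of the limit stays open. Any true difference between the two fluoro placements also stays open.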